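Hydroxylation of an inactive biaryl series

This account rests on a few compounds, and the source may have more. Where it says the series, first, only, none or still open, it means among the compounds named here.

compound 1 `COc1cc(-c2ccccc2)cc(O)c1O`: in a functional assay on SK-MEL-2 cells (Homo sapiens) for cytotoxicity, read by sulforhodamine B assay (a higher number here means a weaker inhibitor, a lower number a stronger inhibitor), compound 1 gives > 10000 nM, which is a limit of the assay.
compound 2 `COc1cc(O)cc(-c2ccccc2)c1`: in this assay compound 2 gives > 10000 nM, also a limit.
compound 3 `COc1cc(OC)cc(-c2ccccc2)c1`: in this assay compound 3 gives > 10000 nM, again a limit.

From compound 2 to compound 1 the change is hydroxy in place of hydrogen on an aromatic carbon, and the step is a step that the two limits leave unreadable from compound 2 to compound 1. The cores of compound 3 and compound 2 differ by methyl in place of hydrogen on an oxygen on an aromatic ring, with the step that the two limits leave unreadable from compound 2 to compound 3. Compound 4 `COc1cc(OC)cc(-c2ccc(O)cc2)c1` is not yet measured; it differs from compound 3 by hydroxy in place of hydrogen on an aromatic carbon. This is the same kind of change as that from compound 2 to compound 1, but the place differs: there the hydroxy enters ortho to a hydroxy group, ortho to a methoxy group and para to a group of 6 heavy atoms, whereas in compound 4 it enters para to a large group. The earlier step of this kind is unreadable, so its size gives no guide. For compound 4 the expected step in this assay is a step that the limit leaves unreadable from compound 3 to compound 4, resting on the fact that (the limit of > 10000 nM in this assay, at which 3 of the 3 values shown sit). Compound 4 is estimated at 15000 nM, between 5000 nM and 40000 nM, and a further limit is expected.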

Compound 4, half-maximal inhibitory concentration: > 10000 nM
Compound 4: only a limit was reported; the forecaster's own chance of this, stated with the estimate: 80%; the middle value does not contradict the limit.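

Compound 3 and compound 4 both sit at a limit in this assay, so no step between them can be read: the limit of > 10000 nM in this assay, at which 4 of the 4 values shown sit.

The compounds shown leave open how strongly any of them acts and whether hydroxy in place of hydrogen changes that.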